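Piperidinylcarbonyl in place of the open-chain group of compound 3

This account rests on a few compounds, and the source may have more. Where it says the series, first, only, none or still open, it means among the compounds named here.

Three members of the series have numbers in a functional assay for antagonist activity at C-X-C chemokine receptor type 3 (Homo sapiens); on this read-out higher numbers stand for weaker inhibition and lower numbers for stronger inhibition. Compound 1 `CNC(=O)c1cnc(N2CCN(C3CCN(Cc4ccccn4)CC3)[C@@H](C)C2)c(Cl)c1` gives 7990 nM, compound 2 `CNC(=O)c1cnc(N2CCN(C3CCN(Cc4ccc(C)cc4)CC3)[C@@H](C)C2)c(Cl)c1` gives 87 nM, and compound 3 `CCNC(=N)c1cnc(N2CCN(C3CCN(Cc4ccc(Cl)cc4)CC3)[C@@H](C)C2)c(Cl)c1` gives 83 nM. On these numbers compound 3 stands lowest, with compound 2 nearest and compound 1 furthest; the gap to compound 2 is within the scatter, so no order between those two can be claimed. Among the compounds with values here, the only single-point step measured is a 92-fold lower number from compound 1 to compound 2 (1.96 log units; beyond the scatter), which concerns the group on the saturated chain carbon bound to the ring amine nitrogen and not the aromatic carbon touched here.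

Compound 4 `C[C@H]1CN(c2ncc(C(=O)N3CCCCC3)cc2Cl)CCN1C1CCN(Cc2ccc(Cl)cc2)CC1` differs from compound 3 by a group of 8 heavy atoms (6 carbon, 1 nitrogen, 1 oxygen; one six-membered non-aromatic ring with 1 hetero atom) in place of a group of 5 heavy atoms (3 carbon, 2 nitrogen; no ring), on an aromatic carbon. Within the data shown here, no measured step bears on this position: compounds 2 and 3 differ at two places at once, and their two values simply lie within the scatter of each other. The change removes both hydrogen-bond donors of the leaving group and brings in a six-membered non-aromatic ring, so there is no direct guide in the series, and the expectation rests on the lack of any shown change at this position. A modest step upward, a 2.4-fold higher number from compound 3 to compound 4 (0.38 log units; beyond the scatter), is expected, with a wide range. Compound 4 is therefore estimated at 200 nM, between 50 nM and 1000 nM.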

Compound 4, half-maximal inhibitory concentration: 900 nM
Estimate against measurement, compound 4: 4.5-fold (0.65 log units) below; the measured number falls inside the stated range.
By their numbers in this assay, from the lowest: compounds 3 and 2 (each within the scatter of the next); then compound 4; then compound 1.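

Position note: the aromatic carbon two atoms from the ring nitrogen is not indifferent to the group it carries, since in this assay (piperidin-1-yl)carbonyl in place of the open-chain group gives an 11-fold higher number from compound 3 to compound 4 (1.04 log units; beyond the scatter). Within the data shown here, this is the only step read at this position, and it is large. The step changes several things at once: the leaving group has 2 hydrogen-bond donors and no ring, while the entering group has 0 hydrogen-bond donors, one six-membered non-aromatic ring with 1 hetero atom and more heavy atoms, and no measurement is at hand to explain the higher number.

The compounds shown leave open whether the higher number goes with the missing donors or with the added ring, and a dimethylaminocarbonyl group, which has neither a ring nor an amide hydrogen, would help to separate the two. As far as these compounds go, it is also open how far this position tolerates other kinds of group, such as a carboxylic acid, a nitrile or a morpholine amide.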